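This account rests on a few compounds, and the source may have more. Where it says the series, first, only, none or still open, it means among the compounds named here.

Measured so far in an ADME assay on BJ cells (Homo sapiens) for cytotoxicity, read by MTT assay, with a stated time of 72 h; a higher number here means a weaker inhibitor, a lower number a stronger inhibitor:
compound 1 `Oc1ccccc1CNc1ncnc2c1ncn2C1CCCCO1` gives > 100000 nM, a limit of the assay.
compound 2 `COc1ccccc1CNc1ncnc2c1ncn2C1CCCCO1` gives > 100000 nM, a limit of the assay.
compound 3 `COc1ccc(CNc2ncnc3c2ncn3C2CCCO2)cc1OC` gives > 100000 nM, a limit of the assay.

For the measured compounds named here, every value so far sits at the limit of > 100000 nM in this assay, at which 3 of the 3 values shown sit. Compound 4 `COc1cc(CNc2ncnc3c2ncn3C2CCCO2)ccc1O` is not yet measured. It arises from compound 3 by hydrogen in place of methyl on an oxygen on an aromatic ring. The same change has been made once before: compound 1 arises from compound 2 by hydrogen in place of methyl on an oxygen on an aromatic ring, and since the two place descriptions agree word for word, this is the same change, occurring twice among the compounds shown. Its measured size is a step that the two limits leave unreadable from compound 2 to compound 1. How the core of compound 3 differs from the core of compound 2 is not broken down here.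

For compound 4, in this assay, the step is expected to be a step that the limit leaves unreadable from compound 3 to compound 4. This expectation rests on the earlier step that the two limits leave unreadable from compound 2 to compound 1, which gave no readable movement. It also rests on compound 3 sitting at > 100000 nM. Compound 4 is therefore expected to give 150000 nM, estimated between 50000 nM and 500000 nM, most likely again as a limit.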

Compound 4, half-maximal inhibitory concentration: > 100000 nM
Compound 4 ended at the assay's limit (the forecaster's own chance of this, stated with the estimate: 85%); the middle value does not contradict the limit.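

In this assay compound 4 gives > 100000 nM, which is a limit of the assay. No step can be read between compound 3 and compound 4, nor for the same methoxy to hydroxy change between compound 2 and compound 1. The compounds shown leave open the size of that change, because every value sits at one limit: the limit of > 100000 nM in this assay, at which 4 of the 4 values shown sit.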